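This account rests on a few compounds, and the source may have more. Where it says the series, first, only, none or still open, it means among the compounds named here.

Measured so far:
Compound 1 `CC(C)(C)OC(=O)N1CCN(C(=S)SCc2cn(-c3ccccc3F)nn2)CC1` — in a functional assay on PC-3 cells (Homo sapiens) for inhibition, read by MTT assay, with a stated time of 72 h (on this read-out lower numbers stand for stronger inhibition and higher numbers for weaker inhibition), compound 1 gives a limit of the assay, > 128000 nM.
Compound 2 `COc1ccc(Cn2cc(CSC(=S)N3CCN(C(=O)OCc4ccccc4)CC3)nn2)cc1` — in this assay compound 2 also gives only a limit, > 128000 nM.

Compound 2 thus stands at the limit rather than at a measured number, and the other value shown is a limit as well: the limit of > 128000 nM in this assay, at which 2 of the 2 values shown sit. Neither compound gives a point on the scale from which a step could be measured.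

Compound 3 `Cc1ccc(Cn2cc(CSC(=S)N3CCN(C(=O)OCc4ccccc4)CC3)nn2)cc1` differs from compound 2 in one place: methyl in place of methoxy on an aromatic carbon. Among the compounds with values here, no measured step of this kind is available here, so the expectation rests on the two limits alone. Compound 3 is expected to remain at the limit, with a step from compound 2 that is expected to be none beyond the scatter, a step that the limit leaves unreadable from compound 2 to compound 3. Compound 3 is estimated at 200000 nM, within a range from 60000 nM to 1000000 nM, most likely reported again as a limit.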

Compound 3, half-maximal inhibitory concentration: > 128000 nM
Compound 3: only a limit was reported; the forecaster's own chance of this, stated with the estimate: 85%; the middle value does not contradict the limit.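

Compound 2 and compound 3 both stop at a limit, so no step can be read between them, whether methoxy or methyl stands on the aromatic ring: the limit of > 128000 nM in this assay, at which 3 of the 3 values shown sit. In this assay the compounds shown leave open which structural change, if any, would give a measured number on the scale.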